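The compounds below may be only part of what the source reports. "The series", "measured", "known", "first", "only" and "open" are said of these compounds alone.

Values in a functional assay on HeLa cells (Homo sapiens) for antiproliferative activity, read by MTT assay, with a stated time of 72 h; on this read-out lower numbers stand for stronger inhibition and higher numbers for weaker inhibition:
compound 1 `COc1cc(-c2nccn2Cc2ccccc2)cc(OC)c1OC`: > 100000 nM, a limit of the assay and not a number
compound 2 `COc1ccc(-n2ccnc2-c2cc(OC)c(OC)c(OC)c2)cc1[N+](=O)[O-]`: 2500 nM
compound 3 `COc1ccc(-n2ccnc2-c2cc(OC)c(OC)c(OC)c2)cc1`: 1200 nM

Among these three, compound 3 has the lowest number, at 1200 nM. The nearest measured number belongs to compound 2, at 2500 nM. Placing 4-methoxyphenyl in place of benzyl on an aromatic nitrogen gives an at least 83-fold lower number from compound 1 to compound 3 (1.92 log units; beyond the scatter), a large step, but that change lies elsewhere in the molecule and offers little guidance for what comes next.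

The next compound, compound 4 `COc1ccc(-n2ccnc2-c2cc(OC)c(OC)c(OC)c2)cc1N`, keeps all of compound 3 except for one change: amino in place of hydrogen on an aromatic carbon. Amino takes the place of hydrogen on an aromatic carbon, ortho to a methoxy group. The closest measured comparison is the change from nitro to hydrogen on that carbon, which gives a 2.1-fold lower number from compound 2 to compound 3 (0.32 log units; beyond the scatter), a modest step. Amino itself has not been measured there, so the direction remains uncertain. Given that modest step, a similarly modest change is expected rather than a large one, leaning slightly towards stronger inhibition. The expected step is a 2.4-fold lower number from compound 3 to compound 4 (0.38 log units; beyond the scatter). For compound 4, the estimated value in this assay is 500 nM, with an expected range from 60 nM to 2500 nM.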

Compound 4, half-maximal inhibitory concentration: 80 nM
For compound 4 the middle estimate is 6.3-fold (0.80 log units) above the measured one, and the stated range covers the measured number.
By their numbers in this assay, from the lowest: compound 4; then compound 3; then compound 2. At a limit, above all of these: compound 1.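

In this assay, this carbon, ortho to a methoxy group, proves far more responsive than the earlier nitro-to-hydrogen comparison suggested, since amino in place of hydrogen gives a 15-fold lower number from compound 3 to compound 4 (1.18 log units; beyond the scatter). Setting amino directly against nitro on the same carbon gives a 31-fold lower number from compound 2 to compound 4 (1.49 log units; beyond the scatter). Nitro and amino fall on opposite sides of compound 3. The identity of the group at this carbon matters, not merely whether hydrogen has been replaced. The entering amino has only 1 heavy atom, so even a very small change at this place can produce a large step.

Nothing shown here explains why amino has this effect. It also remains open how far the result depends on amino itself, as the compounds shown do not reveal how a methylamino group, an acetamide or a hydroxyl group would behave on this carbon, or whether amino would give a similar step elsewhere on the same ring.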